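Propoxycarbonyl to benzyloxycarbonyl on the shared core

The compounds below may be only part of what the source reports. "The series", "measured", "known", "first", "only" and "open" are said of these compounds alone.

Measured in a functional assay on HT-29 cells (Homo sapiens) for antiproliferative activity, read by MTT assay, with a stated time of 48 h; a lower number here means a stronger inhibitor of growth, a higher number a weaker inhibitor of growth:
compound 1 `COc1ccc(C2=NN(C(=O)OCc3ccccc3)C(c3cc(OC)c(OC)c(OC)c3)C2)cc1`: > 10000 nM
compound 2 `CCCOC(=O)N1N=C(c2cccc(O)c2)CC1c1cc(OC)c(OC)c(OC)c1`: 15200 nM

Compound 1 shows the entry > 10000 nM, which is a limit, not a number. For the measured compounds named here, compound 2, at 15200 nM, holds the only actual number in this assay.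

Compound 3 `COc1cc(C2CC(c3cccc(O)c3)=NN2C(=O)OCc2ccccc2)cc(OC)c1OC` differs from compound 2 in one place: phenyl in place of ethyl on a saturated chain carbon bound to an oxygen next to a carbonyl group. It carries phenyl in place of ethyl on a saturated chain carbon bound to an oxygen next to a carbonyl group, turning propoxycarbonyl into benzyloxycarbonyl. Going by the values given here, no measured pair shows this change. No step beyond the usual scatter is expected in this assay, and the estimated 1.4-fold lower number from compound 2 to compound 3 (0.14 log units; within the scatter) is small. The expected value for compound 3 is 11000 nM, within an estimated range of 3500 nM to 30000 nM.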

Compound 3, concentration for 50% growth inhibition: > 10000 nM
Compound 3 ended at the assay's limit; the forecaster's own chance of this, stated with the estimate: 35%; the middle value is on the limit's open side.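

No step can be read from compound 2 to compound 3 or from compound 1 to compound 3 in this assay, because compound 3 gives only a limit: the limit of > 10000 nM in this assay, at which 2 of the 3 values shown sit.

The compounds shown leave open whether either change, benzyloxycarbonyl for propoxycarbonyl or 3-hydroxyphenyl for 4-methoxyphenyl, alters growth inhibition.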